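This account rests on a few compounds, and the source may have more. Where it says the series, first, only, none or still open, it means among the compounds named here.

In an ADME assay on the whole organism for inhibition, with Echinochloa crus-galli var. formosensis as the target, with a stated time of 4 days (a higher number here means a weaker inhibitor, a lower number a stronger inhibitor), compound 1 `CCCNc1nc(Cl)nc(N[C@@H](C)c2ccccc2)n1` gives 15100 nM as its value. For the measured compounds named here, that number is clearly lower only than the one for compound 2 `CCCNc1nc(Cl)nc(N[C@H](C)c2ccccc2)n1` at 33100 nM in the same test. Compound 3 `CCN(CC)c1nc(Cl)nc(N[C@H](C)c2ccccc2)n1` at 24000 nM stays within the scatter of both.

Compound 4 `CC[C@@H](C)Nc1nc(Cl)nc(N[C@@H](C)c2ccccc2)n1` has not yet been measured. It keeps the drawn configuration of compound 1 at the carbon carrying the phenyl ring and turns propylamino into (sec-butyl)amino: methyl in place of hydrogen on a saturated chain carbon bound to a nitrogen on an aromatic ring and a saturated chain carbon is the whole difference.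

Going by the values given here, two measured steps bear on this. The one closest in kind, diethylamino in place of propylamino, is a 1.4-fold lower number from compound 2 to compound 3 (0.14 log units; within the scatter) and so enlarged that amino group without a change beyond the scatter. The other, a 2.2-fold higher number from compound 1 to compound 2 (0.34 log units; beyond the scatter) in size, goes with the fact that compounds 1 and 2 differ only in the configuration as drawn and so offers no guide to a change in the amino group.

A small step is therefore expected in this assay, with no clear direction. The estimated change is a 1.1-fold lower number from compound 1 to compound 4 (0.03 log units; within the scatter) and would stay inside the scatter. For compound 4 the expected value is 14000 nM as a best estimate. Its estimated range runs from 5500 nM to 36000 nM for this compound.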

Compound 4, half-maximal inhibitory concentration: 7410 nM
The estimate for compound 4 lay 1.9-fold (0.28 log units) above the measured number; the measured number falls inside the stated range.
By their numbers in this assay, from the lowest: compound 4; then compounds 1, 3 and 2 (each within the scatter of the next, the first and the last beyond it).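

The methyl that turns propylamino into (sec-butyl)amino, added on a saturated chain carbon bound to a nitrogen on an aromatic ring and a saturated chain carbon, gives a 2.0-fold lower number from compound 1 to compound 4 (0.31 log units; beyond the scatter) in this assay. This shows that a single added methyl on this amino group can take the number beyond the scatter and toward stronger inhibition, which the earlier change on the same group did not show: a 1.4-fold lower number from compound 2 to compound 3 (0.14 log units; within the scatter). Nothing measured here explains why this step goes in this direction.

The compounds shown leave open whether the other drawn configuration at the new methyl-bearing carbon gives a similar number, and whether the same methyl has a similar effect with the configuration of compound 2 at the carbon carrying the phenyl ring. They also leave open how a tert-butyl or cyclopentyl group on that nitrogen would compare.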